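Growth-inhibition notes: one trifluoromethyl removed

The source may hold more compounds than are shown below. What is called first, only, known or untested is meant among the compounds shown, and "the series" means these compounds.

Measured so far:
compound 1 `O=C(Nc1cccc(-n2cc(-c3ccncc3)c(-c3cc(O)cc(Cl)c3)n2)c1)Nc1ccc(Cl)c(Cl)c1`: -52%
compound 2 `COc1cc(Cl)cc(-c2nn(-c3cccc(NC(=O)Nc4ccc(Cl)c(C(F)(F)F)c4)c3)cc2-c2ccncc2)c1`: -85%
compound 3 `COc1cc(Cl)cc(-c2nn(-c3cccc(NC(=O)Nc4cc(C(F)(F)F)cc(C(F)(F)F)c4)c3)cc2-c2ccncc2)c1`: -83%

In a functional assay on SK-MEL-2 cells (Homo sapiens) for inhibition, read by sulforhodamine B assay, with a stated time of 48 h, tested at 100 uM (a higher number here means a weaker effect of the compound at the concentration tested, a lower number a stronger effect), compound 3 gives -83%, the second highest of the three numbers. Compound 2 gives -85%, within the scatter of compound 3. Among the measured compounds shown here, compound 1 gives -52%, a higher number beyond the scatter; no single-change step links it to the others.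

Compound 4 `COc1cc(Cl)cc(-c2nn(-c3cccc(NC(=O)Nc4cccc(C(F)(F)F)c4)c3)cc2-c2ccncc2)c1` differs from compound 3 by hydrogen in place of trifluoromethyl on an aromatic carbon. For the measured compounds named here, no measured pair shows this change, so the size of the step in this assay is uncertain; a small move toward a higher number, not clearly beyond the scatter, is the working expectation. Compound 4 is therefore estimated at -75% (range -95% to -50%), an expected step of a number 8 percentage points higher from compound 3 to compound 4 (within the scatter).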

Compound 4, a percentage reported as activity, at one concentration (the size of the read-out at that concentration, not a potency): -68%
Compound 4: the middle estimate sits 7 percentage points below what was measured; measured number inside the range.
By their numbers in this assay, from the lowest: compounds 2 and 3 (each within the scatter of the next); then compound 4; then compound 1.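

In this assay, hydrogen in place of trifluoromethyl gives a number 15 percentage points higher from compound 3 to compound 4 (beyond the scatter) beyond the scatter of neither direction in doubt, so this position responds to the change. Hydrogen in place of chloro gives a number 17 percentage points higher from compound 2 to compound 4 (beyond the scatter) on the same ring, so in these compounds either second group, trifluoromethyl or chloro, gives a stronger effect than hydrogen alone. Nothing available explains these steps.

As far as these compounds go, how an amine or a carboxylic acid would read at this position remains open. From the compounds shown here alone, whether these steps carry over to the core of compound 1 also remains open.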